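A few compounds are considered here, and "the series" means these few. Any claim that something is new, unique, unknown or untested is made for them only; others in the source may bear on it.

In a functional assay on MCF7 cells (Homo sapiens) for inhibition, with a stated time of 96 h (on this read-out higher numbers stand for weaker inhibition and lower numbers for stronger inhibition), compound 1 `COc1cc(C(=O)c2cn(-c3cccc(C)c3)cc2-c2ncco2)cc(OC)c1OC` gives 75 nM, compound 2 `COc1cc(C(=O)c2cn(-c3ccc(F)cc3)cc2-c2ccsc2)cc(OC)c1OC` gives 15 nM and compound 3 `COc1cc(C(=O)c2cn(-c3ccc(F)cc3)cc2-c2ncco2)cc(OC)c1OC` gives 93 nM. Compound 3 belongs to the upper pair of numbers. That pair cannot be told apart, as a 1.2-fold higher number from compound 1 to compound 3 (0.09 log units; within the scatter) shows, while the remaining gap is clear, at a 6.2-fold higher number from compound 2 to compound 3 (0.79 log units; beyond the scatter). Compound 4 `COc1cc(C(=O)c2cn(-c3ccc(F)cc3)cc2-c2cccnc2)cc(OC)c1OC` has pyridin-3-yl in place of 1,3-oxazol-2-yl on an aromatic carbon. Only the modest thiophen-3-yl swap at this same place bears on the change, since the other swap sits on the aromatic nitrogen. Pyridin-3-yl is not thiophen-3-yl, so only part of that gap is expected to return. The expected move is a 2.3-fold lower number from compound 3 to compound 4 (0.37 log units; beyond the scatter), towards a lower number. For compound 4 the estimated value is 40 nM, with an expected range of 13 nM to 120 nM.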

Compound 4, half-maximal inhibitory concentration: 39 nM
The estimate for compound 4 lay 1.0-fold (0.01 log units) above the measured number, within the range that was stated.
By their numbers in this assay, from the lowest: compound 2; then compounds 4, 1 and 3 (each within the scatter of the next, the first and the last beyond it).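

In this assay the changes, a 2.4-fold lower number from compound 3 to compound 4 (0.38 log units; beyond the scatter) and a 2.6-fold higher number from compound 2 to compound 4 (0.41 log units; beyond the scatter), leave pyridin-3-yl at a level of its own, short of thiophen-3-yl yet clear of 1,3-oxazol-2-yl. This aromatic carbon thus accepts a six-membered aromatic ring as well as a five-membered one, and the three groups give three separate levels. As far as these compounds go, whether a plain phenyl group here, or an amine on the pyridin-3-yl ring, would move the number further stays open, as does whether this order holds with 3-methylphenyl on the aromatic nitrogen. Nothing shown here explains these differences.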